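This account rests on a few compounds, and the source may have more. Where it says the series, first, only, none or still open, it means among the compounds named here.

Measured in a functional assay on KB cells (Homo sapiens) for cytotoxicity; a lower number here means that less compound is needed, a higher number that more compound is needed for the effect:
- compound 1 `COC1=C(C)C(=O)/C(=C(O)/C=C/c2ccc(C)cc2)C(=O)C1(C)C`: 3.9 ug/mL
- compound 2 `COC1=C(C)C(=O)/C(=C(O)/C=C/c2c(C)cc(C)cc2C)C(=O)C1(C)C`: > 20 ug/mL (a limit of the assay, not a number)
- compound 3 `COC1=C(C)C(=O)/C(=C(O)/C=C/c2cccc3ccccc23)C(=O)C1(C)C`: 2.8 ug/mL

Compound 1 and compound 3 lie within the usual scatter of each other, so compound 1 stands level with the only other numerical result. Compound 4 `COC1=C(C)C(=O)/C(=C(O)/C=C/c2cccs2)C(=O)C1(C)C` has not yet been measured. It carries thiophen-2-yl in place of 4-methylphenyl on a double-bonded chain carbon bound to a double-bonded chain carbon. Going by the values given here, no two measured compounds differ in one place alone, so this expectation rests on the closeness of compound 1 and compound 3, and compound 2 goes against that closeness. The expected change in this assay is a 1.2-fold higher number from compound 1 to compound 4 (0.06 log units; within the scatter), with no shift beyond the scatter in either direction. For compound 4 the estimated value is 4.5 ug/mL, with an expected range from 1.5 ug/mL to 13 ug/mL.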

Compound 4, concentration for half-maximal effect: 5.5 ug/mL
Beside the measured number, compound 4's estimate is 1.2-fold (0.09 log units) below it, and the stated range covers the measured number.
By their numbers in this assay, from the lowest: compounds 3, 1 and 4 (each within the scatter of the next). At a limit, above all of these: compound 2.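

In this assay, going by these compounds alone, thiophen-2-yl in place of 4-methylphenyl gives a 1.4-fold higher number from compound 1 to compound 4 (0.15 log units; within the scatter) and so provides the first comparison of two compounds that differ in one place alone. On a double-bonded chain carbon bound to a double-bonded chain carbon, a five-membered aromatic ring with 1 hetero atom therefore stands level with a six-membered aromatic ring of carbon only. Nothing at hand bears on a cause for this step.

The compounds shown leave open whether a non-aromatic group at this place, such as an amine, a carboxylic acid or a longer chain, would stay level with compound 1. They also leave open how a substituent such as chloro on the thiophen-2-yl ring would read.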